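Swapping the aminophenyl for a trifluorophenyl on a pyrrole

A few compounds are considered here, and "the series" means these few. Any claim that something is new, unique, unknown or untested is made for them only; others in the source may bear on it.

Measured so far:
compound 1 `COc1cc(C(=O)c2cn(-c3ccccc3)cc2-c2ccc(N)cc2)cc(OC)c1OC`: 9 nM
compound 2 `COc1cc(C(=O)c2cn(-c3ccccc3[N+](=O)[O-])cc2-c2ccccc2)cc(OC)c1OC`: 5000 nM

In a functional assay on MCF7 cells (Homo sapiens) for cytotoxicity, read by MTT assay, with a stated time of 96 h (a lower number here means a stronger inhibitor, a higher number a weaker inhibitor), compound 1 gives the lowest of the two numbers; compound 2 sits far higher, beyond the scatter. Compound 3 `COc1cc(C(=O)c2cn(-c3ccccc3)cc2-c2c(F)cc(F)cc2F)cc(OC)c1OC` is not yet measured. It differs from compound 1 in one place: 2,4,6-trifluorophenyl in place of 4-aminophenyl on an aromatic carbon. Among the measured compounds shown here, no step between measured compounds tracks this change, so the expectation rests on compound 1 alone and on compound 2, which also lacks the 4-aminophenyl and gives 5000 nM. A step from compound 1 toward a higher number, beyond the scatter, is expected, a 22-fold higher number from compound 1 to compound 3 (1.35 log units; beyond the scatter). For compound 3 the estimate is 200 nM, within 20 nM to 2000 nM.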

Compound 3, half-maximal inhibitory concentration: 180 nM
The estimate for compound 3 lay 1.1-fold (0.05 log units) above the measured number; low and high end bracket the measured number.
By their numbers in this assay, from the lowest: compound 1; then compound 3; then compound 2.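

In this assay, 2,4,6-trifluorophenyl in place of 4-aminophenyl gives a 20-fold higher number from compound 1 to compound 3 (1.30 log units; beyond the scatter). Among the compounds shown here, this is the first change confined to this position of the shared core, and it shows that the group held here strongly affects the number in this assay. Nothing measured here gives a reason for the step. On these data alone, the amine leaves and three fluorines enter in one move, so the share of each remains open. A 4-fluorophenyl or 4-hydroxyphenyl at the same position would help separate them.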